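A few compounds are considered here, and "the series" means these few. Any claim that something is new, unique, unknown or untested is made for them only; others in the source may bear on it.

In a functional assay on CHO cells for agonist activity at Alpha-2B adrenergic receptor (Homo sapiens) (on this read-out lower numbers stand for an effect already at smaller amounts and higher numbers for an effect only at larger amounts of compound), compound 1 `COC1(C2=NCCN2)COc2c(cccc2-c2ccccc2)O1` gives 15800 nM, the highest of the two numbers recorded so far. For the measured compounds named here, the only other measured compound, compound 2 `CC(Oc1ccccc1/C=N/O)C1=NCCN1`, gives 3980 nM in this assay, a lower value than that of compound 1 and beyond the scatter of repeated measurements; the two compounds are built on different cores, so their values show only that compound 2 acts at smaller amounts than compound 1.

Compound 3 `c1ccc(-c2cccc3c2OCC(C2=NCCN2)O3)cc1` is derived from compound 1 by a single change: hydrogen in place of methoxy on a saturated ring carbon. Going by the values given here, no comparable step between measured compounds exists, so the effect of this change on this assay is not known from the data. Compound 3 is expected to act at smaller amounts than compound 1, with a step of a 4.0-fold lower number from compound 1 to compound 3 (0.60 log units; beyond the scatter) expected in this assay. For compound 3 an estimated value of 4000 nM is expected, within a range from 1000 nM to 16000 nM.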

Compound 3, half-maximal effective concentration: 12600 nM
Beside the measured number, compound 3's estimate is 3.2-fold (0.50 log units) below it; the range from low to high includes it.
By their numbers in this assay, from the lowest: compound 2; then compounds 3 and 1 (each within the scatter of the next).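

For the compounds shown here, replacing methoxy with hydrogen on this saturated ring carbon gives the first reading of this position in this assay, with a 1.3-fold lower number from compound 1 to compound 3 (0.10 log units; within the scatter) between the two compounds. In this pair, removing the methoxy group leaves no change in the read-out that can be told apart from repeated measurement, so the group's presence at this place does not separate the two compounds in this assay. Nothing available accounts for this result.

Only methoxy and hydrogen are shown at this carbon, so it remains open whether a hydroxyl, an ethoxy, an amine or a carboxylic acid there would give a different value. Going by these compounds alone, it is also open whether the same change would have so small an effect on another core, as this is the only pair that differs in one place.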